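Swapping a Formyl Group for a Dimethylamino Chain

This account rests on a few compounds, and the source may have more. Where it says the series, first, only, none or still open, it means among the compounds named here.

Compound 3 `Cn1nc(Cc2nnc(SCCCCCCCC(=O)Nc3ccc(Cl)cc3Cl)n2CCC=O)c2ccccc2c1=O` gives 710 nM in an assay on NK92 cells for inhibition of interleukin-15 (Homo sapiens), read by AlphaScreen, with stated times of 30 min and 1 h (on this read-out higher numbers stand for weaker inhibition and lower numbers for stronger inhibition), the lowest of the two numbers measured. Compound 2 `CCOC(CCn1c(Cc2nn(C)c(=O)c3ccccc23)nnc1SCCCCCCCC(=O)Nc1ccc(Cl)cc1Cl)OCC` gives 30000 nM in this assay. Compound 1 `CCOC(CCn1c(Cc2nn(C)c(=O)c3ccccc23)nnc1SCC(=O)Nc1ccc(Cl)cc1Cl)OCC` gives > 30000 nM in this assay, which is a limit of the assay rather than a number. Among the compounds with values here, the only measured step, a 42-fold lower number from compound 2 to compound 3 (1.63 log units; beyond the scatter), sits at the same place as the change now considered. Compound 4 `CN(C)CCCn1c(Cc2nn(C)c(=O)c3ccccc23)nnc1SCCCCCCCC(=O)Nc1ccc(Cl)cc1Cl` differs from compound 3 by (dimethylamino)methyl in place of formyl on a saturated chain carbon, two bonds along the chain from an aromatic nitrogen. Within the data shown here, no measured step exchanges formyl for (dimethylamino)methyl, so the direction is open. Compound 4 is therefore expected to give about 2000 nM in this assay, ranging from 300 nM to 15000 nM. This estimate means the step of a 2.8-fold higher number from compound 3 to compound 4 (0.45 log units; beyond the scatter), expected with wide uncertainty.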

Compound 4, half-maximal inhibitory concentration: > 30000 nM
Compound 4: no number, only a limit; the forecaster's own chance of this, stated with the estimate: 10%; middle value at least 15-fold (1.17 log units) from the limit.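

Within the data shown here, putting (dimethylamino)methyl in place of formyl gives an at least 42-fold higher number from compound 3 to compound 4 (1.62 log units; beyond the scatter), so diethoxymethyl is not the only group at this place on the chain that goes with much weaker inhibition than formyl. In this assay compound 4 gives > 30000 nM, which is a limit of the assay and not a number. Putting (dimethylamino)methyl in place of diethoxymethyl gives a number no lower from compound 2 to compound 4 (the limit leaves the size open) and this step therefore cannot be read, as the measurements stop at a ceiling: the limit of > 30000 nM in this assay, at which 2 of the 4 values shown sit.

Still open, going by these compounds, is how a carboxylic acid, a primary amine or a longer chain ending in formyl would compare with compound 3 at this place.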